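A few compounds are considered here, and "the series" means these few. Any claim that something is new, unique, unknown or untested is made for them only; others in the source may bear on it.

Of the compounds shown here, three built on one shared core have been measured in a functional assay on Ehrlich cells (Mus musculus) for cytotoxicity, tested at 25 ug/mL; on this read-out lower numbers stand for a weaker effect and higher numbers for a stronger effect at the one concentration tested. Compound 1 `COc1cc(N2C(N)=C(C#N)C(c3ccc([N+](=O)[O-])cc3)C3=C2CC(C)(C)CC3=O)cc(OC)c1OC` gives 50%, compound 2 `COc1cc(N2C(N)=C(C#N)C(c3ccccc3O)C3=C2CC(C)(C)CC3=O)cc(OC)c1OC` gives 0%, and compound 3 `COc1cc(N2C(N)=C(C#N)C(c3ccc(OC)c4ccccc34)C3=C2CC(C)(C)CC3=O)cc(OC)c1OC` gives 30%. Compound 2 thus stands lowest of the three, with a number 50 percentage points lower from compound 1 to compound 2 (beyond the scatter) and a number 30 percentage points higher from compound 2 to compound 3 (beyond the scatter) both beyond the scatter. Compound 4 `COc1cc(N2C(N)=C(C#N)C(c3ccc(C)cc3)C3=C2CC(C)(C)CC3=O)cc(OC)c1OC` is not yet measured; it differs from compound 2 by 4-methylphenyl in place of 2-hydroxyphenyl on a saturated ring carbon. The two measured steps that touch compound 2 bear on this change, one large and one modest, and in each the compound without 2-hydroxyphenyl gives the higher number. For compound 4 a rise beyond the scatter is therefore expected, a number 30 percentage points higher from compound 2 to compound 4 (beyond the scatter). Compound 4 is estimated at 30%, within 5% to 55%.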

Compound 4, a percentage reported as activity, at one concentration (the size of the read-out at that concentration, not a potency): 50%
Compound 4: middle estimate off by 20 percentage points, on the low side; measured number inside the range.
By their numbers in this assay, from the lowest: compound 2; then compound 3; then compounds 1 and 4 (each within the scatter of the next).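

Placing 4-methylphenyl on the saturated ring carbon gives a number 50 percentage points higher from compound 2 to compound 4 (beyond the scatter) and a number 20 percentage points higher from compound 3 to compound 4 (beyond the scatter) in this assay. Methyl in place of nitro on the aromatic carbon gives no change at the digits printed from compound 1 to compound 4 (within the scatter), so the read-out does not separate these two groups on this ring. Nothing available explains these differences. As far as these compounds go, it remains open whether the low number of compound 2 follows from the hydroxy group itself or from its place on the ring. From the compounds shown here alone, how an amine or a carboxylic acid on that ring would read also remains unknown.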